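This account rests on a few compounds, and the source may have more. Where it says the series, first, only, none or still open, it means among the compounds named here.

In a functional assay on HepG2 cells (Homo sapiens) for antiproliferative activity, read by sulforhodamine B assay, with a stated time of 48 h (a higher number here means a weaker inhibitor, a lower number a stronger inhibitor), compound 1 `COc1ccc(/C=C/C(=O)c2ccccc2-c2ccc(OC)c(OC)c2)cc1` gives 600 nM and compound 2 `COc1ccc(OC)c(/C=C/C(=O)c2ccccc2-c2ccc(OC)c(OC)c2)c1` gives 2100 nM while compound 3 `COc1ccc(/C=C/C(=O)c2ccccc2-c2ccc(F)cc2)cc1` gives 93 nM and so stands lowest of the three, beyond the scatter from both others. Compound 4 `COc1ccc(/C=C/C(=O)c2ccccc2-c2ccc(F)cc2)cc1O` departs from compound 3 by a single change, hydroxy in place of hydrogen on an aromatic carbon and this places hydroxy in place of hydrogen on an aromatic carbon, ortho to a methoxy group. For the measured compounds named here, only one measured step touches this part of the structure: a 3.5-fold higher number from compound 1 to compound 2 (0.54 log units; beyond the scatter) and this modest rise came with 2,5-dimethoxyphenyl in place of 4-methoxyphenyl. Going by the values given here, that step swaps in a different substitution and none of the measured compounds carries a hydroxy, so it gives only a rough guide to size. In this assay a small move toward a higher number is therefore expected, though a result within the scatter would be no surprise. The estimated step is a 1.4-fold higher number from compound 3 to compound 4 (0.15 log units; within the scatter) and it stays small. For compound 4 the expected value is 130 nM with an estimated range from 35 nM to 480 nM.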

Compound 4, half-maximal inhibitory concentration: 23 nM
Beside the measured number, compound 4's estimate is 5.7-fold (0.75 log units) above it; the whole stated range lies above it.
By their numbers in this assay, from the lowest: compound 4; then compound 3; then compound 1; then compound 2.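

Placing hydroxy on this aromatic carbon, ortho to a methoxy group and meta to a large group, gives a 4.0-fold lower number from compound 3 to compound 4 (0.61 log units; beyond the scatter) in this assay, so a new group at this carbon can lower the number, even from the lowest value seen until then. For the compounds shown here, the only earlier step on this ring, a 3.5-fold higher number from compound 1 to compound 2 (0.54 log units; beyond the scatter), went the other way, so across these two steps the direction depends on the substitution, though the two steps start from different compounds and swap in different groups. Nothing available here accounts for the drop.

From the compounds shown here alone, whether an amine or a second methoxy group on this same carbon would match the hydroxy remains open. So does whether the same hydroxy change would lower the number on the core of compound 1.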